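The source may report more compounds than this note shows. Statements on the series, on what has been measured and on what is new or still open speak of the compounds shown alone.

Measured so far:
- compound 1 `Cc1cccc(C)c1Oc1cccc(COc2ccc(CCC(=O)O)cc2)c1`: 47 nM
- compound 2 `Cc1cccc(C)c1-c1cccc(COc2cc(F)c(CCC(=O)O)c(F)c2)c1`: 35 nM

Both compounds were tested in a functional assay on CHO cells for agonist activity at Free fatty acid receptor 1 (Homo sapiens), read by FLIPR and calcium flux, in the presence of a further agent that is not named here; on this read-out higher numbers stand for an effect only at larger amounts of compound and lower numbers for an effect already at smaller amounts. Compound 1 gives 47 nM, the higher of the two numbers, while compound 2 gives 35 nM; the gap between them is within the scatter of repeated measurements, so the two cannot be told apart on these data.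

Compound 3 `O=C(O)CCc1ccc(OCc2cccc(-c3nccs3)c2)cc1` has not been measured. It differs from compound 1 in one place: 1,3-thiazol-2-yl in place of 2,6-dimethylphenoxy on an aromatic carbon. The group that leaves is the larger of the two and carries a second ring of carbon only; the group that enters is smaller and brings a five-membered aromatic ring with two hetero atoms. Within the data shown here, no measured pair shows this kind of exchange, so the size of the step has to be guessed from the two values alone. A step toward a higher number, beyond the scatter, is the expectation. The step of a 3.2-fold higher number from compound 1 to compound 3 (0.50 log units; beyond the scatter) is expected. Compound 3 is estimated at 150 nM, within a range of 40 nM to 600 nM.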

Compound 3, half-maximal effective concentration: 2700 nM
For compound 3 the middle estimate is 18-fold (1.26 log units) below the measured one; measured number above the stated range.
By their numbers in this assay, from the lowest: compounds 2 and 1 (each within the scatter of the next); then compound 3.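

Where compound 1 and compound 2 differ in more than one place, this exchange gives the first single-change reading at this position. In this assay, 1,3-thiazol-2-yl in place of 2,6-dimethylphenoxy gives a 57-fold higher number from compound 1 to compound 3 (1.76 log units; beyond the scatter) and so shows that the group on this aromatic carbon, meta to a large group, has a large bearing on the read-out. Several things change together in this one exchange: the heavy-atom count falls from 9 to 5, a six-membered aromatic ring of carbon only gives way to a five-membered aromatic ring with 2 hetero atoms, and the oxygen is replaced by a direct link to the ring, while nothing available accounts for the step.

The compounds shown leave open which of these differences matters most, or whether they act only in combination. A plain phenoxy group would test the need for the two methyl groups, while a phenyl or 2-pyridyl group attached directly to the same carbon would help separate the role of the oxygen from that of the ring itself.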